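Growth inhibition on extending the piperazine methyl

A few compounds are considered here, and "the series" means these few. Any claim that something is new, unique, unknown or untested is made for them only; others in the source may bear on it.

Three compounds share one core and differ only in the saturated ring on the aromatic carbon. In a functional assay on U-937 cells (Homo sapiens) for inhibition, read by MTT assay and WST assay, with a stated time of 72 h, tested at 10 uM (on this read-out lower numbers stand for less inhibition of growth and higher numbers for more inhibition of growth at the one concentration tested), compound 1 `Cc1nc(Nc2ccc3sc(C(=O)Nc4c(C)cccc4Cl)cc3c2)cc(N2CCCCC2)n1` gives 20.6% and compound 2 `Cc1nc(Nc2ccc3sc(C(=O)Nc4c(C)cccc4Cl)cc3c2)cc(N2CCC(C)CC2)n1` gives 24.6%; the step of a number 4 percentage points higher from compound 1 to compound 2 (within the scatter) lies within the scatter. Compound 3 `Cc1nc(Nc2ccc3sc(C(=O)Nc4c(C)cccc4Cl)cc3c2)cc(N2CCN(C)CC2)n1` gives 40.6%, the highest of the three numbers, with a number 20 percentage points higher from compound 1 to compound 3 (beyond the scatter) and a number 16 percentage points higher from compound 2 to compound 3 (beyond the scatter) both beyond the scatter though modest.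

Compound 4 `CCN1CCN(c2cc(Nc3ccc4sc(C(=O)Nc5c(C)cccc5Cl)cc4c3)nc(C)n2)CC1` carries methyl in place of hydrogen on a saturated chain carbon bound to an amine nitrogen in a ring. Among the measured compounds shown here, the only measured step of the same kind, adding a methyl on a saturated carbon, is a number 4 percentage points higher from compound 1 to compound 2 (within the scatter), which stayed within the scatter; the two larger steps concern a change of ring, not a change of alkyl, and do not bear directly on this one. A step within the scatter is therefore expected, a number 1.4 percentage points higher from compound 3 to compound 4 (within the scatter), with no direction beyond the scatter claimed. For compound 4 the estimate in this assay is 42%, in the range 28% to 56%.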

Compound 4, percent growth inhibition at one concentration: 46.5%
The estimate for compound 4 lay 4.5 percentage points below the measured number; the measured number falls inside the stated range.
By their numbers in this assay, from the lowest: compounds 1 and 2 (each within the scatter of the next); then compounds 3 and 4 (each within the scatter of the next).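

In this assay, extending methyl to ethyl on the piperazine gives a number 5.9 percentage points higher from compound 3 to compound 4 (within the scatter), so this first change of alkyl at this position separates nothing, and the ethyl can be carried there with the number staying in the range of the methyl. Against the two compounds without the piperazine, the 4-ethylpiperazin-1-yl group gives a number 21.9 percentage points higher from compound 2 to compound 4 (beyond the scatter) and a number 25.9 percentage points higher from compound 1 to compound 4 (beyond the scatter), so compound 3 and compound 4 together form one group above compound 1 and compound 2, and the separation holds for both alkyl groups. No evidence is at hand on what lies behind these numbers.

From the compounds shown here alone, whether a longer chain such as propyl, or a hydroxyethyl or a carboxylic acid on the chain, would stay in that range remains open. Going by these compounds, with one concentration per compound, the shape of the response also stays open.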